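Moving a Hydroxyl Group on a Pyridine-Based Topoisomerase Inhibitor

A few compounds are considered here, and "the series" means these few. Any claim that something is new, unique, unknown or untested is made for them only; others in the source may bear on it.

Four compounds share one core, a six-membered aromatic ring with one nitrogen carrying three aryl groups. Compound 1 has the structure `Oc1ccc(-c2cc(-c3cccc(Cl)c3)nc(-c3ccccn3)c2)cc1`; in an assay on isolated protein for inhibition of DNA topoisomerase 1 (Homo sapiens), with a stated time of 30 min, tested at 20 uM (on this read-out higher numbers stand for a stronger effect at the one concentration tested and lower numbers for a weaker effect), compound 1 gives 0%. Compound 2 has the structure `Oc1ccc(-c2cc(-c3cccc(Cl)c3)nc(-c3ccco3)c2)cc1`; in this assay compound 2 returned "not determined" (no result reported). Compound 3 has the structure `Oc1cccc(-c2cc(-c3cccnc3)nc(-c3cccc(Cl)c3)c2)c1`; in this assay compound 3 also returned "not determined" (no result reported). For the measured compounds named here, compound 3 therefore stands without any number, and no step between measured compounds can be drawn from it.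

Compound 4 has the structure `Oc1ccc(-c2cc(-c3cccnc3)nc(-c3cccc(Cl)c3)c2)cc1` and is not yet measured. The change from compound 3 to compound 4 is 4-hydroxyphenyl in place of 3-hydroxyphenyl on an aromatic carbon. Going by the values given here, with no number for compound 3, no size or direction of this step in this assay can be stated; the only measured neighbour, compound 1, shows no effect at the concentration tested.

Given that compound 1 gives 0%, compound 4 is expected to show about 5% in this assay, with a range from 0% to 20%.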

Compound 4, a percentage reported as inhibition, at one concentration (the size of the read-out at that concentration, not a potency): 0%
Beside the measured number, compound 4's estimate is 5 percentage points above it, within the range that was stated.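

In this assay, replacing the pyridin-2-yl group with pyridin-3-yl gives no change at the digits printed from compound 1 to compound 4 (within the scatter), and compound 4 gives 0%. Moving the ring nitrogen within this pyridine group therefore does not bring out any inhibition at the one concentration tested, with the 4-hydroxyphenyl and 3-chlorophenyl groups kept in place. Nothing else measured here accounts for this lack of effect.

From the compounds shown here alone, with no number for compound 3, the step from 3-hydroxyphenyl to 4-hydroxyphenyl opposite the ring nitrogen cannot be read, so the effect of moving the hydroxyl group remains unknown. Also open, going by these compounds, is whether an amine or a carboxylic acid in place of the hydroxyl group on that phenyl ring would give any measurable inhibition.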